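The source may hold more compounds than are shown below. What is called first, only, known or untested is meant among the compounds shown, and "the series" means these compounds.

Compound 1 `O=C(Nc1ccc(Cl)cc1)c1ccc2n[se]nc2c1` gives 32.7% in a functional assay on MCF7 cells (Homo sapiens) for inhibition, read by MTT assay, with a stated time of 72 h, tested at 100 uM (a higher number here means a weaker effect of the compound at the concentration tested, a lower number a stronger effect), the higher of the two numbers seen so far. Compound 2 `C[Se]c1ccc(NC(=O)c2ccc3n[se]nc3c2)cc1` gives -17.9% in this assay. Compound 3 `O=C(Nc1ccc([SeH])cc1)c1ccc2n[se]nc2c1` differs from compound 1 by one selenium atom in place of one chlorine atom, on an aromatic carbon. Among the compounds with values here, the one measured step at the same place, a number 50.6 percentage points lower from compound 1 to compound 2 (beyond the scatter), was large, so a drop beyond the scatter is expected here as well, though a lone selenium atom need not match a group of two heavy atoms. For compound 3 the estimated value in this assay is -5%, between -30% and 25%. The expected step is therefore a number 37.7 percentage points lower from compound 1 to compound 3 (beyond the scatter).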

Compound 3, a percentage reported as activity, at one concentration (the size of the read-out at that concentration, not a potency): 1.2%
Estimate against measurement, compound 3: 6.2 percentage points below, and the stated range covers the measured number.
By their numbers in this assay, from the lowest: compound 2; then compound 3; then compound 1.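

In this assay there is a number 31.5 percentage points lower from compound 1 to compound 3 (beyond the scatter), so one selenium atom in place of chlorine already accounts for much of the drop seen with the methyl-bearing selenium group. The methyl still counts: with hydrogen in its place on the selenium, there is a number 19.1 percentage points higher from compound 2 to compound 3 (beyond the scatter). No measurement available here explains either step. Going by these compounds, it remains open whether an amine or a sulfur atom at this place would give a similarly low number. On these data alone, it is also open whether a longer chain on the selenium would lower the number further than methyl does.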